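Adding a Thiophenylcarbonyl Group Where Earlier Steps Were Unreadable

This account rests on a few compounds, and the source may have more. Where it says the series, first, only, none or still open, it means among the compounds named here.

Compound 1 `OB1OCc2ccc(-n3cccc3)cc21` was tested in an ADME assay on L929 cells (Mus musculus) for cytotoxicity, read by resazurin assay, with a stated time of 72 h; a higher number here means a weaker inhibitor, a lower number a stronger inhibitor. In this assay compound 1 gives > 10 ug/mL, which is a limit of the assay rather than a number. Two related compounds are likewise known only as limits. Compound 2 `O=C(O)c1cccn1-c1ccc2c(c1)B(O)OC2` gives > 10 ug/mL, a limit. Compound 3 `CNC(=O)c1cccn1-c1ccc2c(c1)B(O)OC2` gives > 10 ug/mL, again a limit. Because all three sit at the limit of > 10 ug/mL in this assay, at which 3 of the 3 values shown sit, the steps between them cannot be read: a step that the two limits leave unreadable from compound 1 to compound 2, a step that the two limits leave unreadable from compound 1 to compound 3 and a step that the two limits leave unreadable from compound 2 to compound 3. Compound 4 `O=C(c1ccn(-c2ccc3c(c2)B(O)OC3)c1)c1cccs1` has not been measured; it differs from compound 1 by (thiophen-2-yl)carbonyl in place of hydrogen on an aromatic carbon. The earlier steps shown here, each placing a group on an aromatic carbon, give no readable size or direction, so no step beyond the scatter is expected, and compound 4 is expected to give 15 ug/mL (from 5 ug/mL to 50 ug/mL), a step that the limit leaves unreadable from compound 1 to compound 4.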

Compound 4, half-maximal inhibitory concentration: > 10 ug/mL
Compound 4 gave a limit, no number (the forecaster's own chance of this, stated with the estimate: 75%); the middle value lies beyond the limit too.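

Compound 4, like compound 1, gives only a limit and not a number, so no step between them can be read: the limit of > 10 ug/mL in this assay, at which 4 of the 4 values shown sit.

The compounds shown leave open whether any added group changes the result in this assay.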